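The compounds below may be only part of what the source reports. "The series", "measured", "known", "first", "only" and "open" are said of these compounds alone.

Compound 1 `CC1(C)CO[C@@H]1CN([C@H](CCC(F)(F)F)C(N)=O)S(=O)(=O)c1ccc(Cl)cc1` gives 22.3 10^-6 cm/s in an ADME assay on MDCKII-LE cells (Canis lupus familiaris) for permeability, read by transwell migration, in the apical to basolateral direction; on this read-out lower numbers stand for lower permeability and higher numbers for higher permeability. Compound 2 `NC(=O)[C@@H](CCC(F)(F)F)N(C[C@H]1CCOC1)S(=O)(=O)c1ccc(Cl)cc1` gives 21.7 10^-6 cm/s in this assay. Compound 3 `NC(=O)[C@@H](CCC(F)(F)F)N(C[C@@H]1CCOC1)S(=O)(=O)c1ccc(Cl)cc1` gives 20.5 10^-6 cm/s in this assay.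

Compound 1 has the highest of the three numbers, yet its steps to the others, a 1.0-fold lower number from compound 1 to compound 2 (0.01 log units; within the scatter) and a 1.1-fold lower number from compound 1 to compound 3 (0.04 log units; within the scatter), stay within the scatter, as does a 1.1-fold lower number from compound 2 to compound 3 (0.02 log units; within the scatter) between the two stereoisomers (the fact that compounds 2 and 3 differ only in the configuration as drawn). Compound 4 `NC(=O)[C@@H](CCC(F)(F)F)N(C[C@H]1CCO1)S(=O)(=O)c1ccc(Cl)cc1` differs from compound 1 as follows: oxetan-2-yl in place of 3,3-dimethyloxetan-2-yl on a saturated chain carbon bound to a sulfonamide nitrogen. The measured steps replace the same group with a five-membered ring without moving the number, so the account expects no step beyond the scatter here either, estimated as a 1.2-fold lower number from compound 1 to compound 4 (0.07 log units; within the scatter). Compound 4 is therefore expected to give about 19 10^-6 cm/s, with a range from 11 10^-6 cm/s to 33 10^-6 cm/s.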

Compound 4, apparent permeability: 28.7 10^-6 cm/s
Compound 4: the middle estimate sits 1.5-fold (0.18 log units) below what was measured; measured number inside the range.
By their numbers in this assay, from the lowest: compounds 3, 2, 1 and 4 (each within the scatter of the next).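

Exchanging 3,3-dimethyloxetan-2-yl for oxetan-2-yl on a saturated chain carbon bound to a sulfonamide nitrogen leaves this assay within the scatter (a 1.3-fold higher number from compound 1 to compound 4 (0.11 log units; within the scatter)). Oxetan-2-yl also stays within the scatter of both oxolan-3-yl stereoisomers (a 1.4-fold higher number from compound 3 to compound 4 (0.15 log units; within the scatter); a 1.3-fold higher number from compound 2 to compound 4 (0.12 log units; within the scatter)), so this read-out separates none of the four cyclic ether groups at this position. What is known here gives no reason for this.

The compounds shown leave open whether the read-out stays level with an amine or a carboxylic acid at this position. An open-chain ether is equally unresolved.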